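A Methyl Added to a Highly Stable Compound

The source may hold more compounds than are shown below. What is called first, only, known or untested is meant among the compounds shown, and "the series" means these compounds.

In an ADME assay on microsomes from liver (Mus musculus) for metabolic stability, with a stated time of 10 min (on this read-out higher numbers stand for a more stable compound and lower numbers for a less stable compound), compound 3 `O=C(O)[C@H]1CC[C@H](C(=O)N2CC[C@](c3ccc(C(F)(C(F)(F)F)C(F)(F)F)cc3)(S(=O)(=O)c3ccccc3)C2)CC1` gives 96% and holds the highest number in this small set. Compound 2 `CS(=O)(=O)N1CCC(C(=O)N2CC[C@](c3ccc(C(F)(C(F)(F)F)C(F)(F)F)cc3)(S(=O)(=O)c3ccc(F)cc3)C2)CC1` gives 69% which lies lower, beyond the usual scatter. For compound 1 `CC(=O)N1CCC(C(=O)N2CC[C@](c3ccc(C(F)(C(F)(F)F)C(F)(F)F)cc3)(S(=O)(=O)c3ccc(F)cc3)C2)CC1` the entry reads "not determined" (no result reported) and offers no comparison. Compound 4 `Cc1ccc(S(=O)(=O)[C@@]2(c3ccc(C(F)(C(F)(F)F)C(F)(F)F)cc3)CCN(C(=O)[C@H]3CC[C@H](C(=O)O)CC3)C2)cc1` still awaits its result in this assay and, compared with compound 3, carries methyl in place of hydrogen on an aromatic carbon. Within the data shown here, no measured pair shows this change, and compound 3 at 96% has little room to climb. The estimated step of a number 6 percentage points lower from compound 3 to compound 4 (within the scatter) is expected to be a small fall within the scatter. Compound 4 is expected at 90% with an estimated range from 75% to 100% as its upper end.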

Compound 4, percent of the compound remaining: 85%
Compound 4: the middle estimate sits 5 percentage points above what was measured; the measured number falls inside the stated range.
By their numbers in this assay, from the lowest: compound 2; then compound 4; then compound 3.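

In this assay, among these compounds, the change from phenylsulfonyl to (4-methylphenyl)sulfonyl gives a number 11 percentage points lower from compound 3 to compound 4 (beyond the scatter), the first step in this set that changes only one place. It shows that this aromatic carbon, para to a large group, is not a silent position: one added methyl carbon is enough to move the number beyond the usual scatter. No measurement here explains the fall. As far as these compounds go, whether it is special to methyl stays open, since a chlorine atom, a methoxy group or a longer chain such as ethyl could be compared at this same carbon. One pair also leaves open whether methyl acts alike when the carboxylic acid is replaced by an amine.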